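A larger amine at the end of the chain

This account rests on a few compounds, and the source may have more. Where it says the series, first, only, none or still open, it means among the compounds named here.

Of the compounds shown here, two sharing one core have so far been measured in a functional assay on A549 cells (Homo sapiens) for antiproliferative activity, read by MTT assay, with a stated time of 72 h; a lower number here means a stronger inhibitor, a higher number a weaker inhibitor. Compound 1 `COc1cc2c(Oc3c(F)cc(NC(=O)NN4C(=O)CSC4c4c(F)cccc4F)cc3F)ccnc2cc1OCCCN1CCCC1` gives 560 nM. Compound 2 `CCN(CC)CCCOc1cc2nccc(Oc3c(F)cc(NC(=O)NN4C(=O)CSC4c4c(F)cccc4F)cc3F)c2cc1OC` gives 450 nM. Among the compounds with values here, the only step between them, a 1.2-fold lower number from compound 1 to compound 2 (0.09 log units; within the scatter), lies within the scatter, so compound 2 holds the lower of the two numbers only nominally, with compound 1 indistinguishable from it. Compound 3 `COc1cc2c(Oc3c(F)cc(NC(=O)NN4C(=O)CSC4c4c(F)cccc4F)cc3F)ccnc2cc1OCCCN1CCC(N2CCCCC2)CC1` has not yet been measured. It differs from compound 2 in one place: 4-(piperidin-1-yl)piperidin-1-yl in place of diethylamino on a saturated chain carbon, three bonds along the chain from an oxygen on an aromatic ring. Within the data shown here, the single measured step bears on this change only loosely, since it swapped two small amines at this place without any shift beyond the scatter, whereas the group entering here brings more heavy atoms and two rings, and no measured step shows what such a group does at this place. The expectation in this assay is therefore no step beyond the scatter, with wide uncertainty. Compound 3 is thus estimated at 450 nM, in a range from 180 nM to 1200 nM, which corresponds to an expected step of no change at the digits printed from compound 2 to compound 3 (within the scatter).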

Compound 3, half-maximal inhibitory concentration: 380 nM
Compound 3: the middle estimate sits 1.2-fold (0.07 log units) above what was measured, within the range that was stated.
By their numbers in this assay, from the lowest: compounds 3, 2 and 1 (each within the scatter of the next).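

The larger amine changes the picture at this place only in what it extends to. In this assay, 4-(piperidin-1-yl)piperidin-1-yl in place of diethylamino gives a 1.2-fold lower number from compound 2 to compound 3 (0.07 log units; within the scatter) and the same group in place of pyrrolidin-1-yl gives a 1.5-fold lower number from compound 1 to compound 3 (0.17 log units; within the scatter), so both steps stay within the scatter. The earlier compounds had shown this only for an exchange of two small amines, whereas these steps show that a group with two six-membered non-aromatic rings and a second nitrogen can stand on this saturated chain carbon, three bonds along the chain from an oxygen on an aromatic ring, without a step beyond the scatter in this assay. No measurement of any other kind is available to explain why the three numbers stay so close.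

The three compounds all end in an amine, so they leave open what a morpholine, a carboxylic acid or a plain hydroxyl at the chain end would do. They also leave open whether a shorter or longer chain carrying the same amines would keep the numbers within the scatter of one another.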